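Shortening the Unsaturated Acyl Chain on an Acetylated Thioglycoside

The source may hold more compounds than are shown below. What is called first, only, known or untested is meant among the compounds shown, and "the series" means these compounds.

Compound 1 `CCCCCCCC/C=C\CCCCCCCC(=O)Nc1nnc(S[C@@H]2O[C@H](COC(C)=O)[C@H](OC(C)=O)[C@H](OC(C)=O)[C@H]2OC(C)=O)s1` pairs a long unsaturated acyl amide with a fully acetylated sugar. In a functional assay on MDA-MB-231 cells (Homo sapiens) for cytotoxicity, read by MTT assay, with a stated time of 24 h (a lower number here means a stronger inhibitor, a higher number a weaker inhibitor), compound 1 gives 23600 nM, the lower of the two numbers recorded. Compound 2 `C=CCCCCCCCCC(=O)Nc1nnc(S[C@@H]2O[C@H](CO)[C@H](O)[C@H](O)[C@H]2O)s1`, which differs in both the chain and the free sugar hydroxyls, gives 80600 nM in this assay, a higher number than compound 1 by a margin beyond the scatter; as the two compounds differ in more than one place, this shows only what the two values themselves show.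

Compound 3 `C=CCCCCCCCCC(=O)Nc1nnc(S[C@@H]2O[C@H](COC(C)=O)[C@H](OC(C)=O)[C@H](OC(C)=O)[C@H]2OC(C)=O)s1` keeps the acetylated sugar of compound 1 and changes only the chain: allyl in place of dec-1-en-1-yl on a saturated chain carbon, seven bonds along the chain from a carbonyl carbon. Among the compounds with values here, no measured step isolates this change. A small step toward a higher number, possibly within the scatter, is expected a 1.7-fold higher number from compound 1 to compound 3 (0.23 log units; within the scatter). Compound 3 is estimated at 40000 nM in this assay, with a likely range from 15000 nM to 100000 nM.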

Compound 3, half-maximal inhibitory concentration: 60900 nM
Beside the measured number, compound 3's estimate is 1.5-fold (0.18 log units) below it, and the stated range covers the measured number.
By their numbers in this assay, from the lowest: compound 1; then compounds 3 and 2 (each within the scatter of the next).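

In this assay, the change from dec-1-en-1-yl to allyl on a saturated chain carbon, seven bonds along the chain from a carbonyl carbon, gives a 2.6-fold higher number from compound 1 to compound 3 (0.41 log units; beyond the scatter), a modest step that isolates the chain with the acetylated sugar held fixed. With the chain now matched, compound 3 gives 60900 nM and compound 2, with free sugar hydroxyls, gives 80600 nM, two values within the scatter of each other. No available evidence says why the shorter chain gives the higher number.

A single change cannot show how the number follows chain length, or whether the double bond matters. On these data alone, it also remains open how a fully saturated chain, or a chain ending in an amine or a carboxylic acid, would behave at this position.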